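Cyclopropyl Replaces Pyridin-2-yl on an Amine Nitrogen

This account rests on a few compounds, and the source may have more. Where it says the series, first, only, none or still open, it means among the compounds named here.

Of the compounds shown here, two built on the same core have been measured so far. Compound 1 `CC(=O)NC[C@H]1CN(c2ccc(OC[C@H](O)CNc3cc(C(F)(F)F)cc(C(F)(F)F)c3)c(F)c2)C(=O)O1` gives 3.01 in a physicochemical assay for lipophilicity, read by HPLC; on this read-out higher numbers stand for higher lipophilicity and lower numbers for lower lipophilicity. Compound 2 `CC(=O)NC[C@H]1CN(c2ccc(OC[C@@H](O)CNc3ccccn3)c(F)c2)C(=O)O1` gives 1.37 in this assay, the lower of the two numbers, and its gap to compound 1 lies beyond the usual scatter of repeated measurements.

Compound 3 `CC(=O)NC[C@H]1CN(c2ccc(OC[C@@H](O)CNC3CC3)c(F)c2)C(=O)O1` has not yet been measured. It differs from compound 2 in a single place: cyclopropyl in place of pyridin-2-yl on an amine nitrogen, in words cyclopropyl in place of pyridin-2-yl on an amine nitrogen. Going by the values given here, no measured pair shows this exact exchange, so the size of the step cannot be read from any measured compounds and can only be estimated.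

In this assay a downward step beyond the scatter is expected, a number 0.87 log units lower from compound 2 to compound 3 (beyond the scatter).

Compound 3 is estimated to give 0.5 in this assay, with a range from -0.3 to 1.3.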

Compound 3, partition coefficient: 0.02
Compound 3: middle estimate off by 0.48 log units, on the high side; the measured number falls inside the stated range.
By their numbers in this assay, from the lowest: compound 3; then compound 2; then compound 1.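

In this assay, putting cyclopropyl in place of pyridin-2-yl on an amine nitrogen gives a number 1.35 log units lower from compound 2 to compound 3 (beyond the scatter) and so shows that the read-out responds strongly to the group at this position. Going by these compounds alone, compounds 1 and 2 could not show this, as they differ in more than one place, whereas compound 3 changes only this group and leaves the shared core untouched. No measurement shown here accounts for the size of this step.

One exchange cannot tell whether the step follows from losing an aromatic ring or from having fewer heavy atoms on the nitrogen; a phenyl ring or an isopropyl group at the same place would help to separate the two. On these data alone, whether the same exchange gives a step of similar size on a different core also remains open.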